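Swapping the Thiophene Tail for Dimethoxyphenyl: Cytotoxicity Outlook

The compounds below may be only part of what the source reports. "The series", "measured", "known", "first", "only" and "open" are said of these compounds alone.

Of the compounds shown here, three built on one shared core have been tested in an ADME assay on HepG2 cells (Homo sapiens) for cytotoxicity, read by CellTiter-Glo and resazurin assay, with a stated time of 72 h; a higher number here means that more compound is needed for the effect, a lower number that less compound is needed. Compound 1 `CCOC(=O)CCCCCOc1cccc(CN(C(=O)c2ccc(-c3cccc(NC(C)=O)c3)cc2)C(C)C)c1` carries a 3-acetamidophenyl group and in this assay gives > 26000 nM, which is a limit of the assay rather than a number. Compound 2 `CCOC(=O)CCCCCOc1cccc(CN(C(=O)c2ccc(-c3ccoc3)cc2)C(C)C)c1` carries a furan-3-yl group in the same place and in this assay gives > 26000 nM, again a limit. Compound 3 `CCOC(=O)CCCCCOc1cccc(CN(C(=O)c2ccc(-c3ccc(C(C)=O)s3)cc2)C(C)C)c1` carries a 5-acetylthiophen-2-yl group and in this assay gives > 26000 nM, also a limit. Because all three sit at the limit of > 26000 nM in this assay, at which 3 of the 3 values shown sit, none of the steps between them can be sized: a step that the two limits leave unreadable from compound 1 to compound 2, a step that the two limits leave unreadable from compound 1 to compound 3 and a step that the two limits leave unreadable from compound 2 to compound 3 are all unreadable. Compound 3 therefore stands exactly where every measured compound stands, at the limit.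

Compound 4 `CCOC(=O)CCCCCOc1cccc(CN(C(=O)c2ccc(-c3cc(OC)cc(OC)c3)cc2)C(C)C)c1` differs from compound 3 in a single place: 3,5-dimethoxyphenyl in place of 5-acetylthiophen-2-yl on an aromatic carbon. The three measured steps all bear on this position, and all three are unreadable; what they do show is that three rather different groups there leave the cytotoxicity at the limit. I therefore expect no step beyond the scatter in this assay, which amounts to an expected step that the limit leaves unreadable from compound 3 to compound 4. My estimate for compound 4 is 40000 nM, with a range from 20000 nM to 100000 nM, and most likely it is again reported only as a limit.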

Compound 4, half-maximal effective concentration: > 26000 nM
Compound 4: only a limit was reported; the forecaster's own chance of this, stated with the estimate: 85%; the middle value does not contradict the limit.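

In this assay compound 4 gives > 26000 nM, a limit rather than a number. Its steps from compound 1, compound 2 and compound 3 cannot be read, and all four compounds stand together: the limit of > 26000 nM in this assay, at which 4 of the 4 values shown sit. As far as these compounds go, what stays open is how much of any of these four compounds the effect would take, and whether any group at this position would give a measurable value.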